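The source may hold more compounds than are shown below. What is called first, only, known or untested is meant among the compounds shown, and "the series" means these compounds.

Two measured compounds share one core and differ only at the outer end of the urea. Compound 1 `COc1cc(Cl)cc(-c2nn(-c3cccc(NC(=O)Nc4cc(C(F)(F)F)cc(C(F)(F)F)c4)c3)cc2-c2ccncc2)c1` and compound 2 `COc1cc(Cl)cc(-c2nn(-c3cccc(NC(=O)Nc4ccc(Cl)c(Cl)c4)c3)cc2-c2ccncc2)c1` were both tested in a functional assay on HT-29 cells (Homo sapiens) for inhibition, read by sulforhodamine B assay, with a stated time of 48 h, tested at 0.1 uM; a lower number here means a stronger effect, a higher number a weaker effect of the compound at the concentration tested. In this assay compound 1 gives 101%, and in the same setting compound 2 gives 91%. Where compound 2 stands among the numbers shown is plain: its value is the nearer of the two to the low end, but compound 1 lies only a short distance away, and that gap is within the usual scatter of repeated measurements, so the two compounds cannot be separated on these numbers. Both leave the cells almost untouched at the concentration used.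

Compound 3 `COc1cc(Cl)cc(-c2nn(-c3cccc(NC(=O)Nc4cccc(C(F)(F)F)c4)c3)cc2-c2ccncc2)c1` has not been measured. It differs from compound 2 in a single place: 3-(trifluoromethyl)phenyl in place of 3,4-dichlorophenyl on an amide-type nitrogen. Among the compounds with values here, no step between measured compounds speaks directly to this exchange, so the expectation rests on the two values at hand. Since compound 2 sits near no effect at all, the expected step in this assay from compound 2 to compound 3 is a number 4 percentage points higher from compound 2 to compound 3 (within the scatter), with no change beyond the scatter expected in either direction. Compound 3 is therefore estimated at 95%, within a range of 80% to 108%.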

Compound 3, a percentage reported as activity, at one concentration (the size of the read-out at that concentration, not a potency): 95%
Beside the measured number, compound 3's estimate shows no gap at the digits printed; the range from low to high includes it.
By their numbers in this assay, from the lowest: compounds 2, 3 and 1 (each within the scatter of the next).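

In this assay, 3-(trifluoromethyl)phenyl in place of 3,4-dichlorophenyl on the amide-type nitrogen gives a number 4 percentage points higher from compound 2 to compound 3 (within the scatter) and so adds a third outer ring that cannot be told apart from the dichlorinated one at this concentration. Within the data shown here, compound 3 also allows the first one-place comparison with compound 1: hydrogen in place of trifluoromethyl on an aromatic carbon gives a number 6 percentage points lower from compound 1 to compound 3 (within the scatter) in this assay, so having one trifluoromethyl group or two on this ring makes no difference that these numbers can separate. Nothing measured here offers an explanation for this flat result.

All three outer rings are phenyl rings carrying chlorine or trifluoromethyl, which leaves open whether an unsubstituted phenyl, a phenyl bearing a dimethylamino group or a carboxylic acid, or a cyclohexyl ring would move the number in this assay clearly away from no effect. Also open, going by these compounds, is whether a change elsewhere, such as replacing the methoxy group on the shared core with a longer ethoxy chain, would matter more than the changes at the outer end of the urea.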